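The source may hold more compounds than are shown below. What is called first, only, known or untested is meant among the compounds shown, and "the series" means these compounds.

Compound 2 `CC(C)=CCC1Cc2c(OCCCOc3ccc(Cl)cc3)cc(=O)n(CCCO)c2CC1(C)C` gives 0% in a functional assay on PANC-1 cells (Homo sapiens) for inhibition, read by MTT assay, with a stated time of 24 h, tested at 10 uM (on this read-out higher numbers stand for more inhibition at the one concentration tested (going by the name of the read-out) and lower numbers for less inhibition), the lowest of the two numbers shown, yet compound 1 `CC(C)=CCC1Cc2c(OCCCNC(=O)c3ccco3)cc(=O)n(CCCO)c2CC1(C)C` with 4.3% sits within the scatter of it. The step of a number 4.3 percentage points lower from compound 1 to compound 2 (within the scatter) was within the scatter. Compound 3 `CC(C)=CCC1Cc2c(OCCCOc3ccc([N+](=O)[O-])cc3)cc(=O)n(CCCO)c2CC1(C)C` differs from compound 2 by nitro in place of chloro on an aromatic carbon. No measured step exchanges a group on the six-membered aromatic ring; the only step shown, at a different place, stayed within the scatter. Compound 3 is therefore expected to give an estimated 5% in this assay, between 0% and 20%. For compound 3 the expected step of a number 5 percentage points higher from compound 2 to compound 3 (within the scatter) amounts to none beyond the scatter.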

Compound 3, a percentage reported as inhibition, at one concentration (the size of the read-out at that concentration, not a potency): 0%
The estimate for compound 3 lay 5 percentage points above the measured number; measured number inside the range.
By their numbers in this assay, from the lowest: compounds 2, 3 and 1 (each within the scatter of the next).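

In this assay, within the data shown here, nitro in place of chloro, on an aromatic carbon para to a large group, gives no change at the digits printed from compound 2 to compound 3 (within the scatter), so this is the first reading of an exchange at this ring position. With 4-nitrophenoxy in place of ((furan-2-yl)carbonyl)amino, the chain end gives a number 4.3 percentage points lower from compound 1 to compound 3 (within the scatter), so a second substituted phenoxy group also stays within the scatter of the furan amide. No supporting data accompany these numbers to interpret them. On these data alone, it remains open whether an amine or a carboxylic acid at this ring carbon, or a longer chain carrying the ring, would give a number beyond the scatter in this assay.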